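Cytotoxicity of Aryl Amino Alcohols: Estimating Compound 4

The source may report more compounds than this note shows. Statements on the series, on what has been measured and on what is new or still open speak of the compounds shown alone.

Measured compounds in a toxicity assay on HeLa cells (Homo sapiens) for cytotoxicity; on this read-out higher numbers stand for lower toxicity in this test and lower numbers for higher toxicity in this test:
compound 1, `COc1ncc(-c2ccccc2)cc1[C@@H](c1ccccc1)[C@@](O)(CCN(C)C)c1ccccc1`, gives 11.9 ug/mL
compound 2, `COc1ncc(-c2ccccc2)cc1[C@@H](c1ccccc1)[C@@](O)(CCN(C)C)c1cccc(F)c1F`, gives 28.1 ug/mL
compound 3, `COc1nc(-c2ccccc2F)ccc1[C@@H](c1ccccc1)[C@@](O)(CCN(C)C)c1cccc2ccccc12`, gives "nd" (no result reported)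

As far as these compounds go, compound 3 therefore has no single number on this assay, and where it stands is unknown. Compound 4, `COc1nc(-c2ccc(Cl)c(F)c2)ccc1[C@@H](c1ccccc1)[C@@](O)(CCN(C)C)c1cccc2ccccc12`, differs from compound 3 by 4-chloro-3-fluorophenyl in place of 2-fluorophenyl on an aromatic carbon. Among the measured compounds shown here, the one measured step, a 2.4-fold higher number from compound 1 to compound 2 (0.37 log units; beyond the scatter), alters a different part of the shared core and so does not bear directly on the change from compound 3 to compound 4. Nothing measured touches the aromatic carbon changed here, so no direction beyond the scatter can be expected, and the two measured values set the likely span. Compound 4 is therefore estimated at 18 ug/mL, within a range from 7 ug/mL to 45 ug/mL.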

Compound 4, half-maximal cytotoxic concentration: > 64 ug/mL
Compound 4 ended at the assay's limit (the forecaster's own chance of this, stated with the estimate: 20%); middle value at least 3.5-fold (0.55 log units) from the limit.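

In this assay compound 4 gives > 64 ug/mL, which is a limit of the assay and not a number. Among the compounds shown here, compound 3 has no number either, so no step between compound 3 and compound 4 can be read. As far as these compounds go, how 4-chloro-3-fluorophenyl in place of 2-fluorophenyl changes the result in this assay stays open.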